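A few compounds are considered here, and "the series" means these few. Any claim that something is new, unique, unknown or untested is made for them only; others in the source may bear on it.

Of the compounds shown here, three have been measured in an ADME assay on the whole organism (plasma) for pharmacokinetics, with Rattus norvegicus as the target, with a stated time of 6 h, at a dose of 10 mg/kg by the oral route (a lower number here means less compound in the circulation, a higher number more compound in the circulation at the dose given), so far.
- compound 1 `O=c1c(OC2CCCC2)c(N2CCN(S(=O)(=O)Cc3ccncc3)CC2)cnn1-c1cc(F)cc(F)c1` (20 ng.h/mL)
- compound 2 `Nc1cccc(CS(=O)(=O)N2CCN(c3cnn(-c4cc(F)cc(F)c4)c(=O)c3OC3CCCC3)CC2)c1` (5700 ng.h/mL)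
- compound 3 `CC1(COc2c(N3CCN(S(=O)(=O)Cc4ccc(N)c(C(F)(F)F)c4)CC3)cnn(-c3cccc(Cl)c3)c2=O)CC1` (640 ng.h/mL)

Compound 3 stands second highest of the three, below compound 2 and above compound 1. Compound 4 `CC(C)c1cc(CS(=O)(=O)N2CCN(c3cnn(-c4cccc(Cl)c4)c(=O)c3OCC3(C)CC3)CC2)ccc1N` carries isopropyl in place of trifluoromethyl on an aromatic carbon, ortho to an amino group (isopropyl in place of trifluoromethyl on an aromatic carbon). For the measured compounds named here, the one measured step (a 290-fold higher number from compound 1 to compound 2 (2.45 log units; beyond the scatter)) was large, but it exchanged other groups, 3-aminophenyl in place of pyridin-4-yl, and no measured step covers this exchange. A change beyond the scatter in this assay is therefore not expected, and the estimated step (a 1.3-fold lower number from compound 3 to compound 4 (0.11 log units; within the scatter)) has no firm direction. For compound 4 the value is estimated at 500 ng.h/mL (120 ng.h/mL to 2000 ng.h/mL).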

Compound 4, area under the concentration-time curve: 2100 ng.h/mL
Compound 4: middle estimate off by 4.2-fold (0.62 log units), on the low side; the measured number lies above the stated range.
By their numbers in this assay, from the lowest: compound 1; then compound 3; then compound 4; then compound 2.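

In this assay, isopropyl in place of trifluoromethyl on an aromatic carbon, ortho to an amino group, gives a 3.3-fold higher number from compound 3 to compound 4 (0.52 log units; beyond the scatter), so the group at this position moves the read-out beyond the scatter. For the compounds shown here, this is the only measured step at this position, as the earlier step concerned the group on the saturated chain carbon bound to the sulfonyl sulfur. Nothing given here accounts for the rise.

The compounds shown leave open how a methyl, a tert-butyl or a chlorine at this carbon would read. They also leave open whether the same exchange would carry over to the core of compound 2.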